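Swapping the Aryl Ether Cap on a Macrolide Core

The compounds below may be only part of what the source reports. "The series", "measured", "known", "first", "only" and "open" are said of these compounds alone.

Compound 1, `CC[C@@H]1/C=C(\C)C[C@H](C)C[C@H](OC)[C@H]2O[C@@](O)(C(=O)C(=O)N3CCCC[C@H]3C(=O)O[C@H](/C(C)=C/[C@@H]3CC[C@@H](Oc4ccc(C)cc4)[C@H](OC)C3)[C@H](C)[C@@H](O)CC1=O)[C@H](C)C[C@@H]2OC`, gives 2.7 nM in a functional assay on cells for inhibition, with Murine T-cell line (Mus musculus) as the target; on this read-out lower numbers stand for stronger inhibition and higher numbers for weaker inhibition.
Compound 2, `CC[C@@H]1/C=C(\C)C[C@H](C)C[C@H](OC)[C@H]2O[C@@](O)(C(=O)C(=O)N3CCCC[C@H]3C(=O)O[C@H](/C(C)=C/[C@@H]3CC[C@@H](Oc4ccc(F)cc4)[C@H](OC)C3)[C@H](C)[C@@H](O)CC1=O)[C@H](C)C[C@@H]2OC`, gives 3.4 nM in this assay.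
Compound 3, `CC[C@@H]1/C=C(\C)C[C@H](C)C[C@H](OC)[C@H]2O[C@@](O)(C(=O)C(=O)N3CCCC[C@H]3C(=O)O[C@H](/C(C)=C/[C@@H]3CC[C@@H](Oc4cccc(O)c4)[C@H](OC)C3)[C@H](C)[C@@H](O)CC1=O)[C@H](C)C[C@@H]2OC`, gives 1.7 nM in this assay.

These three compounds share a large common core and differ only in the aromatic group carried on an oxygen on a saturated carbon. Compound 3 sits at the low end of the three numbers, yet the steps leading to it, a 1.6-fold lower number from compound 1 to compound 3 (0.20 log units; within the scatter) and a 2.0-fold lower number from compound 2 to compound 3 (0.30 log units; within the scatter), both lie within the scatter, and so does a 1.3-fold higher number from compound 1 to compound 2 (0.10 log units; within the scatter); on these numbers the three compounds cannot be told apart.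

Compound 4, `CC[C@@H]1/C=C(\C)C[C@H](C)C[C@H](OC)[C@H]2O[C@@](O)(C(=O)C(=O)N3CCCC[C@H]3C(=O)O[C@H](/C(C)=C/[C@@H]3CC[C@@H](Oc4ccc(SC)cc4)[C@H](OC)C3)[C@H](C)[C@@H](O)CC1=O)[C@H](C)C[C@@H]2OC`, has not yet been measured. Its difference from compound 3 is 4-(methylsulfanyl)phenyl in place of 3-hydroxyphenyl on an oxygen on a saturated carbon. Two of the measured steps bear on this change, since each of them also exchanges the whole aromatic group on that oxygen: a 1.6-fold lower number from compound 1 to compound 3 (0.20 log units; within the scatter) and a 2.0-fold lower number from compound 2 to compound 3 (0.30 log units; within the scatter). Both are small, and the third step, a 1.3-fold higher number from compound 1 to compound 2 (0.10 log units; within the scatter), which alters a substituent on that ring, is small as well. Nothing here points to a step beyond the scatter in either direction.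

Compound 4 is therefore expected to give about 2.5 nM in this assay, with a likely range from 1.2 nM to 6 nM. The expected step is a 1.5-fold higher number from compound 3 to compound 4 (0.17 log units; within the scatter).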

Compound 4, half-maximal inhibitory concentration: 2.6 nM
Beside the measured number, compound 4's estimate is 1.0-fold (0.02 log units) below it; measured number inside the range.
By their numbers in this assay, from the lowest: compounds 3, 4, 1 and 2 (each within the scatter of the next).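

The new group is the largest of the aromatic caps shown so far and the first to carry sulfur, yet in this assay exchanging 3-hydroxyphenyl for 4-(methylsulfanyl)phenyl gives a 1.5-fold higher number from compound 3 to compound 4 (0.18 log units; within the scatter) and stays within the scatter, even though the hydrogen-bond donor of compound 3 is gone. Within the phenyl ring series, methylsulfanyl in place of fluoro gives a 1.3-fold lower number from compound 2 to compound 4 (0.12 log units; within the scatter) and methylsulfanyl in place of methyl gives a 1.0-fold lower number from compound 1 to compound 4 (0.02 log units; within the scatter), both within the scatter too, so all four aryl groups on this oxygen remain indistinguishable in this assay. Nothing available explains why these different groups give such closely matched numbers.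

The compounds shown leave open whether any group on this oxygen can move the number beyond the scatter, for instance a phenyl ring bearing an amine or a carboxylic acid, or a longer saturated chain in place of the ring. Also open, from the compounds shown here alone, is whether hydroxyl and methylsulfanyl would behave alike at other places on the ring, as each appears at only one place here.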